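The source may hold more compounds than are shown below. What is called first, only, known or untested is meant among the compounds shown, and "the series" means these compounds.

Three compounds have been tested in a functional assay on HEK293 cells for agonist activity at D(4) dopamine receptor (Homo sapiens), read by FLIPR; on this read-out lower numbers stand for an effect already at smaller amounts and higher numbers for an effect only at larger amounts of compound:

Compound 1 `O=C(CN1CCC(c2cccc[n+]2[O-])CC1)Nc1ccc(F)cc1` gives 85 nM.
Compound 2 `Cc1cccc(NC(=O)CN2CCC(c3ccccc3C)CC2)c1` gives 340 nM.
Compound 3 `O=C(CN1CCC(c2cccc[n+]2[O-])CC1)Nc1ccc(F)cc1C(F)(F)F` gives 473 nM.

Compound 1 has the lowest number of the three; compound 2 lies higher and compound 3 higher still. Going by the values given here, the only step between compounds that differ in one place is a 5.6-fold higher number from compound 1 to compound 3 (0.75 log units; beyond the scatter).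

Compound 4 `O=C(CN1CCC(c2cccc[n+]2[O-])CC1)Nc1cccc(Cl)c1Cl` has not yet been measured. It differs from compound 1 by 2,3-dichlorophenyl in place of 4-fluorophenyl on an amide-type nitrogen. That step from compound 1 to compound 3 is the one that bears on this change, because a 5.6-fold higher number from compound 1 to compound 3 (0.75 log units; beyond the scatter) shows that adding a group to the same aromatic ring raised the number modestly. A modest rise in this assay is therefore expected here as well, though two chlorines on different positions are a new pattern and the uncertainty is wide. Compound 4 is expected at 250 nM, with a range of 80 nM to 800 nM, an expected step of a 2.9-fold higher number from compound 1 to compound 4 (0.47 log units; beyond the scatter).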

Compound 4, half-maximal effective concentration: 180 nM
Compound 4: middle estimate off by 1.4-fold (0.14 log units), on the high side; measured number inside the range.
By their numbers in this assay, from the lowest: compound 1; then compounds 4, 2 and 3 (each within the scatter of the next, the first and the last beyond it).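

Replacing 4-fluorophenyl with 2,3-dichlorophenyl on the amide-type nitrogen gives a 2.1-fold higher number from compound 1 to compound 4 (0.33 log units; beyond the scatter) in this assay and so shows that this ring can lose its fluorine and carry two chlorines at the cost of only a modest step. The earlier step kept the fluorine and added trifluoromethyl, so now two different changes on this ring both give a higher number than compound 1. Nothing available explains these shifts.

Still open, from the compounds shown here alone, is how much of the step comes from losing fluorine and how much from each chlorine, which a phenyl with a single chlorine could help separate. Going by these compounds, how an amine or a methoxy group on this ring would behave also remains unknown.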